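Tert-butyl in place of acetyl: a working note

The source may hold more compounds than are shown below. What is called first, only, known or untested is meant among the compounds shown, and "the series" means these compounds.

For the measured compounds named here, in a functional assay on L5178Y cells (Mus musculus) for antiproliferative activity, read by MTT assay (on this read-out lower numbers stand for stronger inhibition and higher numbers for weaker inhibition), compound 2 `CC(=O)c1ccc(OCCCCN2CCN(c3ccccn3)CC2)cc1` gives 24.1 nM, the higher of the two numbers so far. Compound 1 `CC(C)(C)c1ccc(OCCCCN2CCN(c3ncccn3)CC2)cc1`, which also carries tert-butyl, gives 11.3 nM, a gap just beyond the scatter. Going by the values given here, no single-place step has been measured, so the expectation rests on that gap alone. Compound 3 `CC(C)(C)c1ccc(OCCCCN2CCN(c3ccccn3)CC2)cc1` has tert-butyl in place of acetyl on an aromatic carbon. In this assay a modest fall is expected, a 1.7-fold lower number from compound 2 to compound 3 (0.24 log units; within the scatter), possibly not clearly beyond the scatter. The estimate for compound 3 is 14 nM, with an expected range from 6 nM to 32 nM.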

Compound 3, half-maximal inhibitory concentration: 11.9 nM
Estimate against measurement, compound 3: 1.2-fold (0.07 log units) above; the measured number falls inside the stated range.
By their numbers in this assay, from the lowest: compounds 1 and 3 (each within the scatter of the next); then compound 2.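

In (this assay), the change at this aromatic carbon now has a measured size for a single-place step: tert-butyl in place of acetyl gives (a 2.0-fold lower number from compound 2 to compound 3 (0.31 log units; beyond the scatter)). With tert-butyl held, pyridin-2-yl in place of pyrimidin-2-yl on the amine nitrogen in a ring gives (a 1.1-fold higher number from compound 1 to compound 3 (0.02 log units; within the scatter)), so this swap does not separate the two compounds. No measurement on hand bears on the origin of either step.

Going by these compounds, whether an amine or a carboxylic acid on this aromatic carbon would fall with acetyl or with tert-butyl stays open. On these data alone, the effect of a longer chain in the shared core also stays open.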